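Series notes: amide-nitrogen substituent, step to compound 4

The compounds below may be only part of what the source reports. "The series", "measured", "known", "first", "only" and "open" are said of these compounds alone.

Compound 1 `Cc1ccc(OCC(=O)N(Cc2cccs2)c2c[nH]nc2C)cc1` gives 0.4 nM in an assay on HEK293 cells for agonist activity at transient receptor potential cation channel subfamily M member 8 (Homo sapiens), read by fluorescence and calcium flux, with a stated time of 15 min; a higher number here means that more compound is needed for the effect, a lower number that less compound is needed. Compound 2 `Cc1ccc(OCC(=O)N(Cc2cccs2)c2ccnn2C)cc1` gives 422 nM in this assay, and compound 3 `C=CCN(Cc1cccs1)C(=O)COc1ccc(C)cc1` gives 20 nM. Compound 3 therefore holds the second highest number of the three, with compound 2 nearest and compound 1 furthest from it.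

Compound 4 `Cc1ccc(OCC(=O)N(Cc2cccs2)c2ccncc2)cc1` is not yet measured. Its difference from compound 3 is pyridin-4-yl in place of allyl on an amide-type nitrogen.

Going by the values given here, two measured steps bear on a ring entering this position. The step of a 50-fold higher number from compound 1 to compound 3 (1.70 log units; beyond the scatter) shows that removing a 3-methyl-1H-pyrazol-4-yl for allyl costs a great deal, whereas the step of a 21-fold lower number from compound 2 to compound 3 (1.32 log units; beyond the scatter) shows that removing a 1-methyl-1H-pyrazol-5-yl for allyl gains a great deal. Among the compounds with values here, an aromatic ring on the amide-type nitrogen can thus sit far on either side of allyl, and no step in the set involves pyridin-4-yl itself, so direction cannot be fixed from the data. The expected step of a 2.5-fold lower number from compound 3 to compound 4 (0.40 log units; beyond the scatter) is held close to no change beyond the scatter, with a wide range spanning both measured outcomes. Compound 4 is estimated at 8 nM, between 0.5 nM and 150 nM.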

Compound 4, half-maximal effective concentration: 52 nM
Compound 4: middle estimate off by 6.5-fold (0.81 log units), on the low side; measured number inside the range.
By their numbers in this assay, from the lowest: compound 1; then compound 3; then compound 4; then compound 2.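

In this assay the step of a 2.6-fold higher number from compound 3 to compound 4 (0.41 log units; beyond the scatter) puts pyridin-4-yl on the high-number side of allyl, though only modestly, so an aromatic ring on this amide-type nitrogen does not by itself bring the number below that of allyl. The step of an 8.1-fold lower number from compound 2 to compound 4 (0.91 log units; beyond the scatter) and the much larger step a 130-fold higher number from compound 1 to compound 4 (2.11 log units; beyond the scatter) place pyridin-4-yl between the two pyrazole rings, and of the three aromatic rings shown only the 3-methyl-1H-pyrazol-4-yl of compound 1 gives a lower number than allyl, while compound 2 and compound 4 both give higher ones. The identity of the ring therefore matters far more at this position than the mere presence of one, and no measured evidence at hand accounts for the differences among these rings.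

The compounds shown leave open which feature of the 3-methyl-1H-pyrazol-4-yl ring carries the low number of compound 1, since compound 2 differs from it in both the ring attachment and the place of the methyl group. A plain 1H-pyrazol-4-yl, a 1,3-dimethyl-1H-pyrazol-4-yl, a pyridin-3-yl or a phenyl ring on this nitrogen would help to separate these features.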